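Difluorophenyl on the pyrrole nitrogen: expected shift in potency

This account rests on a few compounds, and the source may have more. Where it says the series, first, only, none or still open, it means among the compounds named here.

Three compounds of this series have numbers in a functional assay for agonist activity at sphingosine 1-phosphate receptor 5 (Homo sapiens); on this read-out lower numbers stand for an effect already at smaller amounts and higher numbers for an effect only at larger amounts of compound. Compound 1 `CC/N=C1\S/C(=C\c2cc(C)n(-c3ccccc3)c2C)C(=O)N1CC` gives 237 nM, the second highest of the three. Compound 2 `C/N=C1\S/C(=C\c2cc(C)n(Cc3ccccc3F)c2C)C(=O)N1C` gives 51 nM, the lowest number of the set. Compound 3 `COCC/N=C1\S/C(=C\c2cc(C)n(-c3ccc(F)cc3F)c2C)C(=O)N1C` gives 2100 nM, the highest. Compound 4 `CC/N=C1\S/C(=C\c2cc(C)n(-c3ccc(F)cc3F)c2C)C(=O)N1CC` is not yet measured. From compound 1 to compound 4 the change is 2,4-difluorophenyl in place of phenyl on an aromatic nitrogen. Among the measured compounds shown here, no measured pair shows this change on its own; compound 3 carries the same 2,4-difluorophenyl but differs from compound 1 elsewhere as well, so its number is only a loose hint. A step in this assay from compound 1 to compound 4 of a 2.5-fold higher number from compound 1 to compound 4 (0.40 log units; beyond the scatter) toward a higher number is expected, because compound 3 gives 2100 nM. Compound 4 is estimated at 600 nM, within 150 nM to 2500 nM.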

Compound 4, half-maximal effective concentration: 6180 nM
Compound 4: the middle estimate sits 10-fold (1.01 log units) below what was measured; the measured number lies above the stated range.
By their numbers in this assay, from the lowest: compound 2; then compound 1; then compound 3; then compound 4.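

In this assay the swap of phenyl for 2,4-difluorophenyl on the aromatic nitrogen gives a 26-fold higher number from compound 1 to compound 4 (1.42 log units; beyond the scatter) with the rest of compound 1 unchanged. Among the compounds shown here, this is the first reading of this position in isolation, and it shows that the position responds strongly to this change, a large step beyond the scatter. Nothing available explains the size of the step.

Open, going by these compounds, is whether 2-fluorophenyl or 4-fluorophenyl alone would carry the step. Also open, on these data alone, is how a pyridyl ring or a benzyl group would behave on this same nitrogen with the rest of compound 1 kept.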